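The source may report more compounds than this note shows. Statements on the series, on what has been measured and on what is new or still open speak of the compounds shown alone.

Three compounds were tested in a functional assay on HeLa cells (Homo sapiens) for cytotoxicity, read by MTT assay, with a stated time of 48 h; on this read-out lower numbers stand for stronger inhibition and higher numbers for weaker inhibition. Compound 3 `COc1cc(COCc2cn(Cc3cc(-c4ccccc4)cnc3Cl)nn2)cc(OC)c1OC` gives 41900 nM, and compound 1 `COc1cc(COCc2cn(Cc3cc(-c4ccc(C)cc4)cnc3Cl)nn2)cc(OC)c1OC` gives 28600 nM. The only difference between them is methyl in place of hydrogen on an aromatic carbon, and this change made a 1.5-fold lower number from compound 3 to compound 1 (0.17 log units; within the scatter). Compound 2 `COc1cc(C2=NOC(COCc3cn(Cc4cc(-c5ccccc5)cnc4Cl)nn3)C2)cc(OC)c1OC` gives 7300 nM in this assay, the lowest of the three numbers and beyond the scatter from both compound 1 and compound 3; the difference between its core and the core of compound 3 is not broken down here.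

Compound 4 `COc1cc(C2=NOC(COCc3cn(Cc4cc(-c5ccc(C)cc5)cnc4Cl)nn3)C2)cc(OC)c1OC` has not yet been measured. Among the compounds with values here, it differs from compound 2 by methyl in place of hydrogen on an aromatic carbon, which is the same change, at the same place, as the one that led from compound 3 to compound 1. Since that earlier step stayed within the scatter, the step expected here is a 1.3-fold lower number from compound 2 to compound 4 (0.12 log units; within the scatter), resting on the small size of a 1.5-fold lower number from compound 3 to compound 1 (0.17 log units; within the scatter) and on compound 2 already standing at 7300 nM. Compound 4 is therefore expected to give 5500 nM in this assay, with a plausible range from 2500 nM to 12000 nM.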

Compound 4, half-maximal inhibitory concentration: 9700 nM
For compound 4 the middle estimate is 1.8-fold (0.25 log units) below the measured one; the measured number falls inside the stated range.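

In this assay, the change from phenyl to 4-methylphenyl on the core of compound 2 gave a 1.3-fold higher number from compound 2 to compound 4 (0.12 log units; within the scatter). Set beside the same change on the other core, the two steps cannot be told apart: the same change on two cores in this assay, a 1.5-fold lower number (0.17 log units; within the scatter) from compound 3 to compound 1 and a 1.3-fold higher number (0.12 log units; within the scatter) from compound 2 to compound 4, 1.9-fold (0.29 log units) apart, within the scatter of two such steps. Within the data shown here, both steps and the gap between them lie within the scatter, so in these two pairs the methyl has no readable effect on either core, and the opposite signs of the two steps carry no meaning; this rests on only two pairs in a single assay, however, and does not show that the change would behave the same way on any further core.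

The compounds shown leave open whether a different group at the same place, such as an amine, a carboxylic acid or a longer chain like butyl, would produce a step beyond the scatter on either core. They also leave open whether the methyl would stay as silent in any other assay.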